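Isopropyl for dimethylamino on a sulfonyl sulfur

This account rests on a few compounds, and the source may have more. Where it says the series, first, only, none or still open, it means among the compounds named here.

Compound 1 `C=CC(=O)Nc1cc(Nc2ncc(Cl)c(Nc3ccccc3S(=O)(=O)C(C)C)n2)c(OC)cc1N(C)CCN(C)C`: 16%
Compound 2 `C=CC(=O)Nc1cc(Nc2nccc(Nc3ccccc3S(=O)(=O)N(C)C)n2)c(OC)cc1N(C)CCN(C)C`: 10%

In an ADME assay on microsomes from liver (Homo sapiens) for metabolic stability, read by LC-MS, using NADPH, with a stated time of 30 min, tested at 1 uM (on this read-out lower numbers stand for a less stable compound and higher numbers for a more stable compound), compound 2 gives 10%, which lies within the usual scatter of the value for compound 1 at 16%. The two numbers therefore cannot be ranked, and both compounds stand together on this short scale. Within the data shown here, no measured pair of compounds differs in a single place, so the data give no direct measure of what any one change does.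

The next compound, compound 3 `C=CC(=O)Nc1cc(Nc2nccc(Nc3ccccc3S(=O)(=O)C(C)C)n2)c(OC)cc1N(C)CCN(C)C`, differs from compound 2 by isopropyl in place of dimethylamino on a sulfonyl sulfur. The 2-(dimethylsulfamoyl)phenyl group thus becomes 2-(isopropylsulfonyl)phenyl.

Among the measured compounds shown here, nothing measured so far points to a large move, since compound 2 at 10% sits within the scatter of the only other value. The estimated change is a number 4 percentage points higher from compound 2 to compound 3 (within the scatter), slightly upward in direction but expected to stay within the scatter. For compound 3 the expected value is 14%, with an estimated range from 5% to 28%.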

Compound 3, percent of the compound remaining: 5%
Beside the measured number, compound 3's estimate is 9 percentage points above it, and the stated range covers the measured number.
By their numbers in this assay, from the lowest: compounds 3, 2 and 1 (each within the scatter of the next, the first and the last beyond it).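

In this assay, isopropyl in place of dimethylamino on a sulfonyl sulfur gives a number 5 percentage points lower from compound 2 to compound 3 (within the scatter), so this exchange, the first one read at this place, does not separate the two groups on this read-out. Among these compounds, the same compound 3 also gives the first single-place comparison that clears the scatter: hydrogen in place of chloro on an aromatic carbon gives a number 11 percentage points lower from compound 1 to compound 3 (beyond the scatter), a modest step that sets the chloro, and not the group on the sulfonyl sulfur, as the one change seen to move this read-out so far. Nothing available explains the size of either step.

The compounds shown leave open whether the chloro step would hold with dimethylamino on the sulfonyl sulfur in place of isopropyl, since only the isopropyl pair carries it. They also leave open what a fluoro or a methyl would give on that aromatic carbon, and whether a methyl or a cyclopropyl on the sulfonyl sulfur would give a step beyond the scatter.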